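The compounds below may be only part of what the source reports. "The series", "measured", "known", "first", "only" and "open" are said of these compounds alone.

Values in an ADME assay on MT4 cells (Homo sapiens) for cytotoxicity, read by MTT assay, with a stated time of 96 h; a higher number here means that more compound is tolerated, a lower number that less compound is tolerated:
- compound 1 `CC(=O)c1ccc2[nH]c(-c3ccc(Cl)cc3)nc2c1`: "not determined" (no result reported)
- compound 2 `C/C(=N\NC(N)=O)c1ccc2[nH]c(-c3ccc(Cl)cc3)nc2c1`: "not determined" (no result reported)
- compound 3 `C/C(=N\NC(N)=S)c1ccc2[nH]c(-c3ccccc3)nc2c1`: >= 100000 nM
- compound 4 `C/C(=N\NC(N)=S)c1ccc2[nH]c(-c3ccc(Cl)cc3)nc2c1`: not yet measured

Compound 3 gives only a limit, >= 100000 nM, and not a single number. Among the measured compounds shown here, that entry is all the numerical evidence so far: the limit of >= 100000 nM in this assay, at which 1 of the 3 values shown sits. For the measured compounds named here, compound 1 and compound 2 both carry the 4-chlorophenyl group but give no number, and no measured pair shows what a change at this place does in this assay.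

Compound 4 differs from compound 3 by chloro in place of hydrogen on an aromatic carbon. This is chloro in place of hydrogen on an aromatic carbon, or phenyl to 4-chlorophenyl.

Going by the values given here, with no measured step to draw on, only a modest change is expected, and it may not exceed the usual scatter. Any visible change is expected to run towards less compound tolerated. This expected direction rests on compound 3 standing at the limit of >= 100000 nM. The expected size is an at least 1.6-fold lower number from compound 3 to compound 4 (0.22 log units; that floor lies within the scatter). The assay may also report only a limit again for compound 4. As a number, compound 4 is estimated at 60000 nM, with an expected range from 15000 nM to 120000 nM.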

Compound 4, half-maximal cytotoxic concentration: 2000 nM
Estimate against measurement, compound 4: 30-fold (1.48 log units) above, and the stated range ends above it.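

Phenyl to 4-chlorophenyl gives an at least 50-fold lower number from compound 3 to compound 4 (1.69 log units; beyond the scatter), the first readable step in the series, and it shows that this single place on the shared core can carry a large change in how much compound the cells tolerate. In this assay compound 3 gives >= 100000 nM, which is a limit and not a number. The size of the step is therefore a floor and not an exact figure, because its starting point is that limit: the limit of >= 100000 nM in this assay, at which 1 of the 4 values shown sits.

Compound 1 and compound 2 also carry the 4-chlorophenyl group but have no reported result, so any steps involving them cannot be read, and it remains unclear whether the lower tolerance at this place also holds with the ketone of compound 1 or the carbonyl of compound 2 in place of the thiocarbonyl side chain of compound 4. As far as these compounds go, it also remains open whether the change is specific to chloro or would also appear with another group at this place, such as fluoro, methoxy, an amine or a carboxylic acid.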